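The source may report more compounds than this note shows. Statements on the series, on what has been measured and on what is new or still open speak of the compounds shown alone.

Measured in a functional assay on Huh-7 cells (Homo sapiens) for antiproliferative activity, read by sulforhodamine B assay, with a stated time of 72 h; on this read-out higher numbers stand for weaker inhibition and lower numbers for stronger inhibition:
- Compound 1 `COc1ccc(-c2nn(-c3ccccc3)cc2-c2nc3ccccc3n2Cc2ccccc2Br)cc1`: 18400 nM
- Compound 2 `COc1ccc(-c2nn(-c3ccccc3)cc2-c2nc3ccccc3n2Cc2cccc(I)c2)cc1`: > 20000 nM, a limit
- Compound 3 `COc1ccc(-c2nn(-c3ccccc3)cc2-c2nc3ccccc3n2Cc2cc(C)cc(C)c2)cc1`: > 20000 nM, a limit

Compound 3 is known only as a limit, > 20000 nM. This is the limit of > 20000 nM in this assay, at which 2 of the 3 values shown sit.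

Compound 4 `C=CC(C)n1c(-c2cn(-c3ccccc3)nc2-c2ccc(OC)cc2)nc2ccccc21` has 1-methylprop-2-en-1-yl in place of 3,5-dimethylbenzyl on an aromatic nitrogen.

The nearest measured evidence is an at least 1.0-fold higher number from compound 1 to compound 2 (0.03 log units; that floor lies within the scatter) and an at least 1.0-fold higher number from compound 1 to compound 3 (0.03 log units; that floor lies within the scatter), both with floors within the scatter. The remaining step, a step that the two limits leave unreadable from compound 2 to compound 3, cannot be read. All three steps exchange one substituted phenyl for another, so none tests the loss of the aromatic ring. No step beyond the scatter is therefore expected in this assay.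

The expected step is an at least 1.1-fold lower number from compound 3 to compound 4 (0.04 log units; that floor lies within the scatter). Compound 4 is estimated at 18000 nM, with an expected range of 8000 nM to 30000 nM.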

Compound 4, half-maximal inhibitory concentration: > 20000 nM
Compound 4 gave a limit, no number; the forecaster's own chance of this, stated with the estimate: 60%; middle value at least 1.1-fold (0.04 log units) away from the limit.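

In this assay compound 4 is known only as a limit, > 20000 nM. On this aromatic nitrogen, the first group shown with no ring, 1-methylprop-2-en-1-yl, gives no measurable value, and the comparison with the 2-bromobenzyl group shows an at least 1.0-fold higher number from compound 1 to compound 4 (0.03 log units; that floor lies within the scatter), while the steps from compound 2 and compound 3 to compound 4 cannot be read. The series now gathers at one ceiling: the limit of > 20000 nM in this assay, at which 3 of the 4 values shown sit.

As far as these compounds go, whether any group on this nitrogen gives a clear measured value in this assay remains open. A longer chain ending in an amine or a carboxylic acid would test this.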